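The source may report more compounds than this note shows. Statements on the series, on what has been measured and on what is new or still open speak of the compounds shown alone.

In a functional assay on NCI-H522 cells (Homo sapiens) for cytotoxicity, read by sulforhodamine B assay, with a stated time of 48 h, tested at 1 uM (a higher number here means a weaker effect of the compound at the concentration tested, a lower number a stronger effect), compound 1 `COc1cc(-c2cc(/C=C/C(=O)c3ccc(N)cc3)[nH]n2)cc(OC)c1OC` gives 77%. Compound 2 `COc1ccc(-c2cc(/C=C/C(=O)c3ccc(N)cc3)[nH]n2)cc1OC` differs from it by hydrogen in place of methoxy on an aromatic carbon, and in this assay compound 2 gives 87%; the step of a number 10 percentage points higher from compound 1 to compound 2 (within the scatter) is small, so the two values cannot be told apart.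

Compound 3 `COc1cc(C(=O)/C=C/c2cc(-c3cc(OC)c(OC)c(OC)c3)n[nH]2)cc(OC)c1OC` is built on a different core, and the difference between the two cores is not broken down here. In this assay compound 3 gives 29%, the strongest effect of the three, with compound 1 and compound 2 both lying well above it.

Compound 4 `COc1ccc(-c2cc(/C=C/C(=O)c3cc(OC)c(OC)c(OC)c3)[nH]n2)cc1OC` is the still unmeasured partner of compound 3. It carries hydrogen in place of methoxy on an aromatic carbon, the same change that turns compound 1 into compound 2, at the same kind of place. Because a number 10 percentage points higher from compound 1 to compound 2 (within the scatter) stayed within the scatter, a comparably small step is expected here, so compound 4 is estimated at 40%, with a number 11 percentage points higher from compound 3 to compound 4 (beyond the scatter) as the expected step, and a range from 22% to 65%.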

Compound 4, a percentage reported as activity, at one concentration (the size of the read-out at that concentration, not a potency): 71%
Estimate against measurement, compound 4: 31 percentage points below, and the stated range ends below it.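

In this assay, putting hydrogen in place of methoxy on the core of compound 3 gives a number 42 percentage points higher from compound 3 to compound 4 (beyond the scatter), so on this core the change takes away much of the effect seen at the concentration tested. The same change therefore does not carry a fixed size from one core to another in this series: the same change on two cores in this assay, a number 10 percentage points higher (within the scatter) from compound 1 to compound 2 and a number 42 percentage points higher (beyond the scatter) from compound 3 to compound 4, 32 percentage points apart, beyond the scatter of two such steps. This rests on just two pairs, read at one concentration in one cell line, so it shows that the core matters to the size of the step, but not why it does, nor what the change would do on a third core.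

The compounds shown leave open whether the effect depends on methoxy itself or simply on having any group at that place, since only methoxy and hydrogen appear there; an ethoxy group, a hydroxyl group or a chlorine atom there would separate the two readings. They also leave open which part of the core of compound 3 makes the step so large.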